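Shortening the amide substituent of compound 2

This account rests on a few compounds, and the source may have more. Where it says the series, first, only, none or still open, it means among the compounds named here.

Two mirror-image compounds have been measured in an assay on SK-OV-3 cells for inhibition of eIF-2-alpha kinase GCN2 (Homo sapiens); on this read-out higher numbers stand for weaker inhibition and lower numbers for stronger inhibition. Compound 1 `COCCNC(=O)[C@H]1CC[C@H](Nc2ncc3c(Br)nn(-c4ccc5ncccc5c4)c3n2)C1` gives 183 nM, while compound 2 `COCCNC(=O)[C@@H]1CC[C@@H](Nc2ncc3c(Br)nn(-c4ccc5ncccc5c4)c3n2)C1` gives 20 nM, the lowest of the two numbers; the step of a 9.2-fold lower number from compound 1 to compound 2 (0.96 log units; beyond the scatter) rests on (the fact that compounds 1 and 2 differ only in the configuration as drawn), the two compounds differing in no other way. Compound 3 `CNC(=O)[C@@H]1CC[C@@H](Nc2ncc3c(Br)nn(-c4ccc5ncccc5c4)c3n2)C1` keeps the configuration of compound 2 and changes only the amide substituent: hydrogen in place of methoxymethyl on a saturated chain carbon bound to an amide-type nitrogen, so that the (2-methoxyethyl)carbamoyl group becomes a methylcarbamoyl group. The measured step between compound 1 and compound 2 concerns configuration alone and says nothing about the amide chain, so no measured change bears directly on this step. In the absence of such evidence, the trimming at a saturated chain carbon bound to an amide-type nitrogen is expected to move the number in this assay only modestly, and the change a 1.4-fold higher number from compound 2 to compound 3 (0.15 log units; within the scatter) is expected to stay near or within the scatter. Compound 3 is therefore estimated at 28 nM in this assay, within a range from 9 nM to 90 nM.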

Compound 3, half-maximal inhibitory concentration: 25 nM
Compound 3: middle estimate off by 1.1-fold (0.05 log units), on the high side; the range from low to high includes it.
By their numbers in this assay, from the lowest: compounds 2 and 3 (each within the scatter of the next); then compound 1.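

In this assay, for the compounds shown here, the step of a 1.3-fold higher number from compound 2 to compound 3 (0.10 log units; within the scatter) gives the first reading at the amide chain, as the earlier pair of compounds spoke only to configuration. In the configuration of compound 2, methoxymethyl on a saturated chain carbon bound to an amide-type nitrogen can give way to hydrogen without a change beyond the scatter, so the (2-methoxyethyl)carbamoyl group and the methylcarbamoyl group cannot be told apart on this read-out, and the 3 heavy atoms that leave, oxygen among them, are not needed to keep the number at the level of compound 2. Nothing measured here ties this step to any property of the chain.

The compounds shown leave open how the number responds when this chain carries something other than these two endings, such as a longer chain, a terminal amine or a carboxylic acid, or when the methyl group itself gives way to the bare amide hydrogen. They also leave open whether the same trimming would read alike in the configuration of compound 1, as the one chain change shown stands in the configuration of compound 2.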